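Ethyl in place of iodo on the shared core

The source may hold more compounds than are shown below. What is called first, only, known or untested is meant among the compounds shown, and "the series" means these compounds.

Measured so far in a functional assay on NFS-60 cells (Mus musculus) for inhibition, with a stated time of 72 h; on this read-out higher numbers stand for weaker inhibition of growth and lower numbers for stronger inhibition of growth:
Compound 1 `Nc1ncnc2c(C(=O)Nc3cccc4c3c(Br)nn4Cc3ccccn3)csc12`: 2500 nM
Compound 2 `Cc1cccc(Cn2nc(Br)c3c(NC(=O)c4csc5c(N)ncnc45)cccc32)n1`: 27.5 nM
Compound 3 `Cc1cccc(Cn2nc(I)c3c(NC(=O)c4csc5c(N)ncnc45)cccc32)n1`: 30 nM

In this assay compound 3 gives 30 nM, level with compound 2 within the usual scatter, while compound 1 shows a far higher number at 2500 nM. The next compound, compound 4 `CCc1nn(Cc2cccc(C)n2)c2cccc(NC(=O)c3csc4c(N)ncnc34)c12`, has not yet been measured. It differs from compound 3 in one place: ethyl in place of iodo on an aromatic carbon. In short, it carries ethyl in place of iodo on an aromatic carbon.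

Two measured steps can be weighed. The one at this same place, iodo in place of bromo, was a 1.1-fold higher number from compound 2 to compound 3 (0.04 log units; within the scatter). The other, methyl in place of hydrogen, was a 91-fold lower number from compound 1 to compound 2 (1.96 log units; beyond the scatter), but it lies at a different place, and compound 4 keeps that methyl. Within the data shown here, no measured compound carries ethyl at the changed place, so the evidence is indirect and the range must stay wide. Only a small step is expected, with a slight lean towards a higher number, and it may not clear the scatter. The estimated change is a 1.3-fold higher number from compound 3 to compound 4 (0.12 log units; within the scatter). For compound 4 the expected value is 40 nM, with an estimated range of 12 nM to 130 nM.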

Compound 4, concentration for 50% growth inhibition: > 10000 nM
Compound 4: no number, only a limit; the forecaster's own chance of this, stated with the estimate: 2%; middle value at least 250-fold (2.39 log units) away from the limit.
By their numbers in this assay, from the lowest: compounds 2 and 3 (each within the scatter of the next); then compound 1. At a limit, above all of these: compound 4.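

Bromo and iodo at this aromatic carbon of the five-membered ring had read alike, so the earlier compounds gave no sign that the position responds strongly to what it carries. Ethyl changes that: in this assay, ethyl in place of iodo gives an at least 330-fold higher number from compound 3 to compound 4 (2.52 log units; beyond the scatter), and ethyl in place of bromo gives an at least 360-fold higher number from compound 2 to compound 4 (2.56 log units; beyond the scatter). Compound 4 shows > 10000 nM, which is a limit of the assay and not a number, so among compound 2, compound 3 and compound 4 the position keeps its activity with either halogen but loses it with ethyl, and the full size of the loss stays unknown: the limit of > 10000 nM in this assay, at which 1 of the 4 values shown sits.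

The compounds shown leave open whether a chloro group, a nitrile or a bare hydrogen at this carbon would read with compound 2 and compound 3 or with compound 4. They also do not tell how far past the limit compound 4 lies, or whether a longer chain such as propyl would read the same as ethyl.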